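Benzyl for Isopropyl on a Shared Core: Cytotoxicity Outlook

The source may hold more compounds than are shown below. What is called first, only, known or untested is meant among the compounds shown, and "the series" means these compounds.

Measured so far:
compound 1, `CN(c1cc2ncc(=O)[nH]c2cc1NC(=S)Nc1cccc2ccccc12)C1CCCCC1`, gives 43600 nM
compound 2, `CC(C)c1nc2cc(N(C)C3CCCCC3)c(Nc3nc(-c4ccccc4)cs3)cc2[nH]c1=O`, gives 67400 nM

Both numbers come from an ADME assay on Huh-7 cells (Homo sapiens) for cytotoxicity; a higher number here means a weaker inhibitor, a lower number a stronger inhibitor. Within the data shown here, compound 2 stands with the highest of the two numbers, but its only neighbour, compound 1, sits within the usual scatter of it, so no order between the two can be read from these values; all that can be said is that the two compounds show values of the same general size in this assay.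

Compound 3, `CN(c1cc2nc(Cc3ccccc3)c(=O)[nH]c2cc1Nc1nc(-c2ccccc2)cs1)C1CCCCC1`, has not yet been measured. It differs from compound 2 in one place: benzyl in place of isopropyl on an aromatic carbon. Among the measured compounds shown here, no measured pair in this set carries that same change, so there is no observed step to lean on, and the expectation rests on compound 2 alone.

With that basis the writer expects the step from compound 2 to compound 3 to be small and, most likely, no larger than the scatter of this assay, in either direction. The expected step is a 1.3-fold lower number from compound 2 to compound 3 (0.13 log units; within the scatter). For compound 3 the estimated value in this assay is 50000 nM, with a range from 20000 nM to 125000 nM.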

Compound 3, half-maximal inhibitory concentration: 42000 nM
Estimate against measurement, compound 3: 1.2-fold (0.08 log units) above, within the range that was stated.
By their numbers in this assay, from the lowest: compounds 3, 1 and 2 (each within the scatter of the next).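

At this place on the shared core, an aromatic carbon next to the ring nitrogen, benzyl in place of isopropyl gives in this assay a step of a 1.6-fold lower number from compound 2 to compound 3 (0.21 log units; within the scatter) and so leaves no readable change. Among these compounds, the exchange takes the group from 3 heavy atoms to 7 and adds a six-membered aromatic ring of carbon only, yet compound 2 and compound 3 still show values of the same general size, which the earlier compounds could not show because neither pair among them differed at this one place. Nothing at hand gives a measured reason for this outcome.

The compounds shown leave open whether this place would respond the same way to an amine, a carboxylic acid or a longer chain, since both groups seen here carry no hydrogen-bond donors or acceptors and no net charge. They also leave open whether benzyl in place of isopropyl would give a similar step if a different group stood elsewhere on the shared core.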